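Replacing 4-bromophenyl with 2,4-dichlorophenyl in compound 2

The compounds below may be only part of what the source reports. "The series", "measured", "known", "first", "only" and "open" are said of these compounds alone.

Compound 1 `O=C(/C(=C\c1ccc(Br)cc1)S(=O)(=O)c1ccc(Br)cc1)c1ccc(Br)cc1`: 10000 nM in a functional assay on DU-145 cells (Homo sapiens) for inhibition, read by trypan blue exclusion, with a stated time of 96 h; on this read-out higher numbers stand for weaker inhibition of growth and lower numbers for stronger inhibition of growth
Compound 2 `COc1ccc(S(=O)(=O)/C(=C/c2ccc(Br)cc2)C(=O)c2ccc(Br)cc2)cc1`: 6000 nM in this assay

Compound 2 sits within the usual scatter of compound 1, so the two cannot be told apart. Among the measured compounds shown here, the single measured step, a 1.7-fold lower number from compound 1 to compound 2 (0.22 log units; within the scatter), is methoxy in place of bromo on an aromatic carbon.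

Compound 3 `COc1ccc(S(=O)(=O)/C(=C/c2ccc(Cl)cc2Cl)C(=O)c2ccc(Br)cc2)cc1` differs from compound 2 in another group: 2,4-dichlorophenyl in place of 4-bromophenyl on a double-bonded chain carbon bound to a double-bonded chain carbon. For the measured compounds named here, no measured compound carries 2,4-dichlorophenyl, so the data give no direct guide to this change. The only indication of how far one swap can move the number here is a 1.7-fold lower number from compound 1 to compound 2 (0.22 log units; within the scatter), a step that stayed within the scatter. No clear shift is therefore expected in this assay, although the uncertainty is wide. The estimated step is a 1.5-fold lower number from compound 2 to compound 3 (0.18 log units; within the scatter). For compound 3 the expected value is 4000 nM, with an estimated range from 1200 nM to 12000 nM.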

Compound 3, concentration for 50% growth inhibition: 20000 nM
Beside the measured number, compound 3's estimate is 5.0-fold (0.70 log units) below it; measured number outside the range, above it.
By their numbers in this assay, from the lowest: compounds 2, 1 and 3 (each within the scatter of the next, the first and the last beyond it).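

Putting 2,4-dichlorophenyl in place of 4-bromophenyl on the double-bonded chain carbon gives a 3.3-fold higher number from compound 2 to compound 3 (0.52 log units; beyond the scatter) in this assay, which means a modest loss of growth inhibition. This is the only step among these compounds that lies beyond the scatter, so a change at this position can move the read-out, whereas the methoxy-for-bromo swap on the other aromatic ring could not be told apart from noise. Nothing available explains why the number rises.

This swap exchanges bromine for chlorine and also adds a second halogen, so the compounds shown cannot separate those two changes. As far as these compounds go, it remains open how a simpler 4-chlorophenyl or an unsubstituted phenyl would behave here, or a ring carrying an amine or a carboxylic acid.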